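Two Quinoline Amides Compared in a Cell Toxicity Assay

This account rests on a few compounds, and the source may have more. Where it says the series, first, only, none or still open, it means among the compounds named here.

Measured compounds:
compound 1 `CCCCCC(=O)NCCCN1CCN(CCCNc2ccnc3cc(Cl)ccc23)CC1` — "not determined" (no result reported)
compound 2 `COc1ccc(C(=O)NCCCN2CCN(CCCNc3ccnc4cc(Cl)ccc34)CC2)cc1OC` — "not determined" (no result reported)
compound 3 `CCOc1ccc(C(=O)NCCCN2CCN(CCCNc3ccnc4cc(Cl)ccc34)CC2)cc1` — 5300 nM

All four compounds share one core, a chloroquinoline joined through a short chain to a piperazine and a second chain ending in an amide. They differ only in the group on the amide carbonyl. Compound 1 carries a pentyl chain, compound 2 a 3,4-dimethoxyphenyl, compound 3 a 4-ethoxyphenyl. In an ADME assay on L6 cells (Rattus norvegicus) for cytotoxicity (a lower number here means a stronger inhibitor, a higher number a weaker inhibitor), compound 3 gives 5300 nM. In this assay compound 2 is recorded as "not determined" (no result reported), and compound 1 as "not determined" (no result reported), so compound 2 cannot be placed on a scale against anything; it stands as an untested neighbour of compound 3.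

Compound 4 `COc1cccc(C(=O)NCCCN2CCN(CCCNc3ccnc4cc(Cl)ccc34)CC2)c1` has not yet been measured. It arises from compound 2 by one change: hydrogen in place of methoxy on an aromatic carbon. For the measured compounds named here, no measured pair shows what such a change does, so the size of its effect in this assay is open. With compound 3 as the only anchor, and its value within reach of a close aryl amide, a step no larger than the usual scatter, in either direction, seems most likely. Compound 4 is therefore estimated at 6000 nM, with a range from 2000 nM to 20000 nM, largely because compound 3 gives 5300 nM.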

Compound 4, half-maximal inhibitory concentration: 9300 nM
The estimate for compound 4 lay 1.6-fold (0.19 log units) below the measured number; measured number inside the range.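

In this assay the exchange of 4-ethoxyphenyl for 3-methoxyphenyl on the carbonyl carbon gives a 1.8-fold higher number from compound 3 to compound 4 (0.24 log units; within the scatter), so this read-out does not separate these two aryl amides, even though the two differ in both the alkoxy group and its place on the ring. For the compounds shown here, the step from compound 2 to compound 4, the 3,4-dimethoxyphenyl to 3-methoxyphenyl change, cannot be read, and the effect of hydrogen in place of methoxy on this aromatic carbon therefore remains unknown, with compound 4 supplying only one side of the comparison. Nothing measured here offers an explanation for the result.

The compounds shown leave open how a pentyl amide such as compound 1 compares with the aryl amides, since compound 1 has no number to set against them. They also leave open whether an amine or a carboxylic acid on the aromatic ring, in place of the methoxy group of compound 4, would move the number beyond the usual scatter.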